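A few compounds are considered here, and "the series" means these few. Any claim that something is new, unique, unknown or untested is made for them only; others in the source may bear on it.

Working notes on the series.

Compound 1 `COc1ccc(SCc2ccc(/C=C/C(=O)Nc3ccccc3N)cc2)cc1OC` carries a 3,4-dimethoxyphenyl on a sulfur attached to the shared core. In a functional assay on HCT-116 cells (Homo sapiens) for inhibition, read by CCK-8 assay, with a stated time of 72 h, tested at 2 uM (on this read-out lower numbers stand for less inhibition of growth and higher numbers for more inhibition of growth at the one concentration tested), compound 1 gives 12.9%. Compound 2 `Nc1ccccc1NC(=O)c1ccc(CSc2ccc(Br)cc2)cc1` gives 9.96% in this assay, and compound 3 `Nc1ccccc1NC(=O)c1ccc(CSc2ccc(C(F)(F)F)cn2)cc1` gives 1.2% in this assay. Compound 1 gives the largest of the three numbers, but its gap to compound 2 lies within the usual scatter of repeated measurements, so no order between compound 1 and compound 2 can be read from these two values; its gap to compound 3 lies beyond the scatter. All three numbers sit in the low range of the read-out.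

Compound 4 `Nc1ccccc1NC(=O)/C=C/c1ccc(CSc2cccc(F)c2)cc1` has not yet been measured in this assay. It differs from compound 1 in one place: 3-fluorophenyl in place of 3,4-dimethoxyphenyl on a sulfur. No measured pair in the set isolates this change, so nothing shown gives its size or direction. Given that every value shown is low, the step from compound 1 to compound 4 is expected to be small, a number 4.9 percentage points lower from compound 1 to compound 4 (within the scatter), and not beyond the scatter in either direction. Compound 4 is therefore estimated at 8% in this assay, with a range from 0% to 20%.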

Compound 4, percent growth inhibition at one concentration: 7.95%
Compound 4: middle estimate off by 0.1 percentage points, on the high side; measured number inside the range.
By their numbers in this assay, from the lowest: compounds 3, 4, 2 and 1 (each within the scatter of the next, the first and the last beyond it).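

In this assay, for the compounds shown here, this is the first step that isolates a change on the sulfur of the shared core, and replacing 3,4-dimethoxyphenyl with 3-fluorophenyl gives a number 5 percentage points lower from compound 1 to compound 4 (within the scatter). On this single pair, going from 10 heavy atoms and 2 hydrogen-bond acceptors in the leaving group to 7 heavy atoms and 0 hydrogen-bond acceptors in the entering group does not shift the read-out beyond the scatter, and the two oxygen-bearing methoxy groups are therefore not required to keep the number at this low level. No measurement shown explains this outcome, so no cause can be assigned to it.

Going by these compounds alone, the steps between compound 2 or compound 3 and the other compounds cannot be read, as no such pair differs in one place. Still open, from the compounds shown here alone, is whether an amine or a carboxylic acid on the aromatic ring attached to the sulfur, or a longer chain in place of that ring, would lift the number out of the low range at the one concentration tested.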